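The source may hold more compounds than are shown below. What is called first, only, known or untested is meant among the compounds shown, and "the series" means these compounds.

Measured so far in an in vivo ADME assay on the whole organism (strain Sprague-Dawley) for pharmacokinetics, with Rattus norvegicus as the target; a lower number here means that a smaller share of the oral dose reaches the circulation, a higher number that a larger share of the oral dose reaches the circulation:
- compound 1 `CCOC[C@H]1C[C@@](CC(C)C)(C(=O)O)N(C(=O)c2ccc(C(C)(C)C)c(OC)c2)[C@H]1c1nccs1`: 120%
- compound 2 `COC[C@H]1C[C@@](CC(C)C)(C(=O)O)N(C(=O)c2ccc(C(C)(C)C)c(OC)c2)[C@H]1c1nccs1`: 59%

Compound 2, at 59%, holds the lower of the two numbers in this assay, beyond the scatter from the other. Compound 3 `COc1cc(C(=O)N2[C@@H](c3nccs3)[C@@H](CO)C[C@@]2(CC(C)C)C(=O)O)ccc1C(C)(C)C` has not yet been measured. It differs from compound 2 as follows: hydrogen in place of methyl on an oxygen on a saturated carbon. This turns methoxymethyl to hydroxymethyl. Going by the values given here, only one measured step bears on this change: a number 61 percentage points lower from compound 1 to compound 2 (beyond the scatter). That large step also put hydrogen in place of methyl, though on a saturated chain carbon bound to an oxygen on a saturated carbon. As the change sits in a different place and rests on one step alone, a smaller step in the same direction is expected. The expected step is a number 24 percentage points lower from compound 2 to compound 3 (beyond the scatter). For compound 3 the estimated value is 35%, with an expected range from 12% to 65%.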

Compound 3, oral bioavailability: 12%
Beside the measured number, compound 3's estimate is 23 percentage points above it; the range from low to high includes it.
By their numbers in this assay, from the lowest: compound 3; then compound 2; then compound 1.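

In this assay the oxygen of this side chain now carries ethyl, methyl or hydrogen, and the number falls with each removal. Going from the methoxymethyl to the hydroxymethyl group gives a number 47 percentage points lower from compound 2 to compound 3 (beyond the scatter) and so shows that the fall does not stop once the ethyl has become methyl; the whole change from ethyl to hydrogen on this oxygen gives a number 108 percentage points lower from compound 1 to compound 3 (beyond the scatter). No measured evidence in hand accounts for this fall.

The compounds shown leave open how a propyl chain on this oxygen, or an amine in place of the hydroxy, would read in this assay. Going by these compounds alone, with only three compounds, all on the same core, they also leave open whether this order would hold if another part of the core were changed.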